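The source may report more compounds than this note shows. Statements on the series, on what has been measured and on what is new or still open speak of the compounds shown alone.

For the measured compounds named here, in a functional assay on MCF7 cells (Homo sapiens) for antiproliferative activity, read by sulforhodamine B assay, with a stated time of 48 h (on this read-out lower numbers stand for stronger inhibition and higher numbers for weaker inhibition), two compounds have numbers so far. Compound 1 `O=C1NCCN1c1ccc(S(=O)(=O)Nc2ccc(F)cc2)cc1` gives 690 nM, and compound 2 `Cc1ccc(NS(=O)(=O)c2ccc(N3CCNC3=O)cc2)c(C)c1` gives 230 nM, the lower of the two numbers and so the stronger inhibition of the pair.

The next compound, compound 3 `Cc1ccccc1NS(=O)(=O)c1ccc(N2CCNC2=O)cc1`, differs from compound 2 in one place: hydrogen in place of methyl on an aromatic carbon, (hydrogen in place of methyl on an aromatic carbon). The 2,4-dimethylphenyl group thus becomes 2-methylphenyl, while the rest of the structure stays the same.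

Going by the values given here, only one measured step bears on this change: a 3.0-fold lower number from compound 1 to compound 2 (0.48 log units; beyond the scatter), which came with 2,4-dimethylphenyl in place of 4-fluorophenyl on a sulfonamide nitrogen. Among the compounds with values here, that step is modest, and it replaced a whole group, so no measurement yet shows what a single methyl does alone. Removing one methyl is a smaller edit, so a smaller step is expected in this assay than a 3.0-fold lower number from compound 1 to compound 2 (0.48 log units; beyond the scatter), probably towards a higher number and possibly within the scatter.

The estimated step is a 1.5-fold higher number from compound 2 to compound 3 (0.18 log units; within the scatter). For compound 3 the expected value is 350 nM, with an estimated range from 140 nM to 850 nM.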

Compound 3, half-maximal inhibitory concentration: 280 nM
Beside the measured number, compound 3's estimate is 1.3-fold (0.10 log units) above it; the measured number falls inside the stated range.
By their numbers in this assay, from the lowest: compounds 2 and 3 (each within the scatter of the next); then compound 1.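

In this assay, for the compounds shown here, the step from compound 2 to compound 3 is the first to isolate a single methyl: removing the methyl para to a large group gives a 1.2-fold higher number from compound 2 to compound 3 (0.09 log units; within the scatter) and so leaves the two compounds indistinguishable in this assay. The comparison with the fluorinated compound also narrows the earlier change, since 2-methylphenyl in place of 4-fluorophenyl still gives a 2.5-fold lower number from compound 1 to compound 3 (0.39 log units; beyond the scatter) even without the second methyl of the 2,4-dimethylphenyl group. No independent measurement is available to explain why the methyl in this position makes so little measurable difference or why either methyl-bearing ring differs from the 4-fluorophenyl ring.

The compounds shown leave open whether the remaining methyl matters, a question that a plain phenyl ring on the sulfonamide nitrogen would address directly. They also leave open whether the position para to the large group accepts only hydrogen or methyl without a clear shift, or whether a methoxy group, an amine or a carboxylic acid there would move the number beyond the scatter.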